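Amide aryl variation across three measured compounds

The compounds below may be only part of what the source reports. "The series", "measured", "known", "first", "only" and "open" are said of these compounds alone.

Compound 1 `COc1ccc2c(=O)c(/C=C/C(=O)Nc3cccc(Cl)c3)coc2c1` gives 11900 nM in a functional assay on HeLa cells (Homo sapiens) for inhibition, read by MTT assay, with a stated time of 48 h; on this read-out higher numbers stand for weaker inhibition and lower numbers for stronger inhibition.
Compound 2 `COc1ccc2c(=O)c(/C=C/C(=O)Nc3ccc(C)cc3)coc2c1` gives 24100 nM in this assay.
Compound 3 `COc1ccc2c(=O)c(/C=C/C(=O)Nc3cc(C)ccc3C)coc2c1` gives 58400 nM in this assay.

Compound 3 stands at the highest number of the three, and both steps leading to it lie beyond the scatter: a 4.9-fold higher number from compound 1 to compound 3 (0.69 log units; beyond the scatter) and a 2.4-fold higher number from compound 2 to compound 3 (0.38 log units; beyond the scatter). Among the measured set, the 3-chlorophenyl compound 1 carries the lowest number, the 4-methylphenyl compound 2 sits in between, as a 2.0-fold higher number from compound 1 to compound 2 (0.31 log units; beyond the scatter) shows.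

Compound 4 `COc1ccc2c(=O)c(/C=C/C(=O)Nc3ccc(Cl)cc3)coc2c1` differs from compound 3 in one place: 4-chlorophenyl in place of 2,5-dimethylphenyl on an amide-type nitrogen. For the measured compounds named here, no measured compound carries 4-chlorophenyl, so no direct step bears on it. The change removes the 2,5-dimethylphenyl, whose presence marks the highest number, and installs a single chlorine-bearing ring, as in compound 1. The steps of a 2.4-fold higher number from compound 2 to compound 3 (0.38 log units; beyond the scatter) and a 4.9-fold higher number from compound 1 to compound 3 (0.69 log units; beyond the scatter) both point toward a lower number once the 2,5-dimethylphenyl leaves; which of compound 1 or compound 2 compound 4 will resemble more closely is open.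

Compound 4 is therefore expected to give a number clearly below that of compound 3, a step of about a 3.9-fold lower number from compound 3 to compound 4 (0.59 log units; beyond the scatter). The estimate for compound 4 in this assay is 15000 nM, with a range from 6000 nM to 40000 nM.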

Compound 4, half-maximal inhibitory concentration: > 100000 nM
Compound 4: no number, only a limit; the forecaster's own chance of this, stated with the estimate: 5%; middle value at least 6.6-fold (0.82 log units) from the limit.
By their numbers in this assay, from the lowest: compound 1; then compound 2; then compound 3. At a limit, above all of these: compound 4.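

In this assay, compound 4 gives a limit and not a number: the limit of > 100000 nM in this assay, at which 1 of the 4 values shown sits.

At this amide-type nitrogen, the ring carrying the chlorine matters, not merely its presence: 4-chlorophenyl in place of 3-chlorophenyl gives an at least 8.4-fold higher number from compound 1 to compound 4 (0.92 log units; beyond the scatter), so a single chlorine-bearing ring does not by itself go with the lowest number in the series. Chloro in place of methyl on an aromatic carbon gives an at least 4.1-fold higher number from compound 2 to compound 4 (0.61 log units; beyond the scatter), while 4-chlorophenyl in place of 2,5-dimethylphenyl gives an at least 1.7-fold higher number from compound 3 to compound 4 (0.23 log units; that floor lies within the scatter), a floor that does not firmly separate compound 4 from compound 3, so the earlier impression that the highest number goes with 2,5-dimethylphenyl no longer holds as a firm reading.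

The compounds shown leave open how far compound 4 lies past its limit, and therefore the true size of all three steps, as well as why the change has this outcome. Also open, on these data alone, is whether 3-methylphenyl or 3-fluorophenyl on the same nitrogen would stay close to compound 1 or move toward compound 4.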